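A few compounds are considered here, and "the series" means these few. Any claim that something is new, unique, unknown or untested is made for them only; others in the source may bear on it.

Values in a functional assay on SW-620 cells (Homo sapiens) for cytotoxicity, read by sulforhodamine B assay, with a stated time of 48 h; on this read-out higher numbers stand for weaker inhibition and lower numbers for stronger inhibition:
- compound 1 `C[C@H]1CC[C@@H]2[C@@H](OC(=O)[C@]23CC(c2ccccc2)=NO3)[C@]2(C)C(=O)C=C[C@@]12O`: 45400 nM
- compound 2 `C[C@H]1CC[C@@H]2[C@@H](OC(=O)[C@]23CC(c2ccc(N(C)C)cc2)=NO3)[C@]2(C)C(=O)C=C[C@@]12O`: 5100 nM
- compound 3 `COc1cc(C2=NO[C@]3(C2)C(=O)O[C@@H]2[C@H]3CC[C@H](C)[C@]3(O)C=CC(=O)[C@@]23C)ccc1O`: 88000 nM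

Compound 3, at 88000 nM, cannot be told apart from the phenyl parent: a 1.9-fold higher number from compound 1 to compound 3 (0.29 log units; within the scatter). It stands well apart from the dimethylamino analogue: a 17-fold higher number from compound 2 to compound 3 (1.24 log units; beyond the scatter). Among the measured compounds shown here, that analogue is also the only compound separated from the parent: an 8.9-fold lower number from compound 1 to compound 2 (0.95 log units; beyond the scatter).

Next in the series is compound 4 `Cc1cccc(C2=NO[C@]3(C2)C(=O)O[C@@H]2[C@H]3CC[C@H](C)[C@]3(O)C=CC(=O)[C@@]23C)c1`, with this change: 3-methylphenyl in place of 4-hydroxy-3-methoxyphenyl on a carbon with a double bond to nitrogen. For the measured compounds named here, no measured compound carries 3-methylphenyl, so the reading is indirect. The step from phenyl to 4-hydroxy-3-methoxyphenyl, a 1.9-fold higher number from compound 1 to compound 3 (0.29 log units; within the scatter), suggests that compound 4 should stay in the same range. The modest gain in an 8.9-fold lower number from compound 1 to compound 2 (0.95 log units; beyond the scatter) belongs to dimethylamino, which is not part of this change, and it is not carried over. The expected change is a 2.0-fold lower number from compound 3 to compound 4 (0.29 log units; within the scatter), a slightly lower number in this assay but no step beyond the scatter. For compound 4 the estimated value is 45000 nM, with an expected range of 18000 nM to 100000 nM.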

Compound 4, half-maximal inhibitory concentration: 15000 nM
Beside the measured number, compound 4's estimate is 3.0-fold (0.48 log units) above it; the whole stated range lies above it.
By their numbers in this assay, from the lowest: compound 2; then compound 4; then compounds 1 and 3 (each within the scatter of the next).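

Both changes on the carbon with a double bond to nitrogen now show that the aromatic group can shift the number without dimethylamino: in this assay, 3-methylphenyl in place of 4-hydroxy-3-methoxyphenyl gives (a 5.9-fold lower number from compound 3 to compound 4 (0.77 log units; beyond the scatter)), and methyl in place of hydrogen on an aromatic carbon gives (a 3.0-fold lower number from compound 1 to compound 4 (0.48 log units; beyond the scatter)). Dimethylamino is therefore no longer the only group separated from the phenyl parent, although compound 2 still has the lowest number (a 2.9-fold higher number from compound 2 to compound 4 (0.47 log units; beyond the scatter)). The data offered here give no measured explanation for these differences.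

A 4-methylphenyl analogue would show whether the methyl effect depends on its place on the aromatic ring. Separate 4-hydroxyphenyl and 3-methoxyphenyl analogues would divide the contributions within compound 3, and a 4-aminophenyl analogue would test how much of the dimethylamino step needs the two methyl groups.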